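One More Chain Step in a Flat Series

This account rests on a few compounds, and the source may have more. Where it says the series, first, only, none or still open, it means among the compounds named here.

In a functional assay on A-431 cells (Homo sapiens) for inhibition, read by MTT assay, with a stated time of 72 h (on this read-out lower numbers stand for stronger inhibition and higher numbers for weaker inhibition), compound 1 (`O=C(CCN=C=S)Nc1ccc2ncnc(Nc3cccc(Br)c3)c2c1`) gives 17100 nM, compound 2 (`O=C(CCCCN=C=S)Nc1ccc2ncnc(Nc3cccc(Br)c3)c2c1`) gives 16300 nM and compound 3 (`O=C(CCCCCN=C=S)Nc1ccc2ncnc(Nc3cccc(Br)c3)c2c1`) gives 14400 nM. Compound 3 therefore stands within the scatter of both other compounds. Compound 4 (`O=C(CCCCCCN=C=S)Nc1ccc2ncnc(Nc3cccc(Br)c3)c2c1`) departs from compound 3 by one change: a group of 4 heavy atoms (2 carbon, 1 nitrogen, 1 sulfur; no ring) in place of a group of 3 heavy atoms (1 carbon, 1 nitrogen, 1 sulfur; no ring), on a saturated chain carbon, five bonds along the chain from a carbonyl carbon. For the measured compounds named here, three measured steps bear on this change, as each also alters the same chain: a 1.0-fold lower number from compound 1 to compound 2 (0.02 log units; within the scatter), a 1.2-fold lower number from compound 1 to compound 3 (0.07 log units; within the scatter) and a 1.1-fold lower number from compound 2 to compound 3 (0.05 log units; within the scatter). All three lie within the scatter, so no step beyond the scatter is expected here, and no direction can be called. The expected size is a 1.0-fold lower number from compound 3 to compound 4 (0.01 log units; within the scatter). Compound 4 is estimated at 14000 nM, with an expected range of 7500 nM to 26000 nM.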

Compound 4, half-maximal inhibitory concentration: 16100 nM
Compound 4: the middle estimate sits 1.2-fold (0.06 log units) below what was measured; the range from low to high includes it.
By their numbers in this assay, from the lowest: compounds 3, 4, 2 and 1 (each within the scatter of the next).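

In this assay, the change at this position, five bonds along the chain from a carbonyl carbon, gives a 1.1-fold higher number from compound 3 to compound 4 (0.05 log units; within the scatter). Set against the shorter chains, compound 4 gives a 1.0-fold lower number from compound 2 to compound 4 (0.01 log units; within the scatter) and a 1.1-fold lower number from compound 1 to compound 4 (0.03 log units; within the scatter), so the longest chain shown also adds no step beyond the scatter, and the four compounds show no trend with chain length. No measured evidence bears on why this chain makes so little difference. The compounds shown leave open whether a still longer chain, or an amine or a carboxylic acid in place of the group that enters here, would give a step beyond the scatter.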